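A few compounds are considered here, and "the series" means these few. Any claim that something is new, unique, unknown or untested is made for them only; others in the source may bear on it.

Measured so far in a functional assay on C6 cells (Rattus norvegicus) for cytotoxicity, read by MTT assay, with a stated time of 24 h, tested at 200 ug/mL; on this read-out lower numbers stand for a stronger effect and higher numbers for a weaker effect at the one concentration tested:
compound 1 `Cc1nnc(SCC(=O)N/N=c2/scc(-c3ccccc3)n2-c2ccccc2)s1`: 59.2%
compound 2 `Cc1nnc(SCC(=O)N/N=c2/scc(-c3ccc(Cl)cc3)n2-c2ccccc2)s1`: 29%

Going by the values given here, compound 2 stands lowest of the two numbers in this assay, with compound 1 the only neighbour. Among the compounds with values here, the single measured step, a number 30.2 percentage points lower from compound 1 to compound 2 (beyond the scatter), came with chloro in place of hydrogen on an aromatic carbon. Compound 3 `COc1ccc(-c2cs/c(=N/NC(=O)CSc3nnc(C)s3)n2-c2ccccc2)cc1` differs from compound 2 by methoxy in place of chloro on an aromatic carbon. Within the data shown here, no measured step covers this exchange; the one step shows only that a substituent at this place moves the number. The expected step is a number 16 percentage points higher from compound 2 to compound 3 (beyond the scatter), a partial return toward compound 1. Compound 3 is therefore estimated at 45%, between 30% and 62%.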

Compound 3, a percentage reported as activity, at one concentration (the size of the read-out at that concentration, not a potency): 22.2%
Compound 3: middle estimate off by 22.8 percentage points, on the high side; the measured number lies below the stated range.
By their numbers in this assay, from the lowest: compounds 3 and 2 (each within the scatter of the next); then compound 1.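

In this assay methoxy in place of chloro, 4-chlorophenyl to 4-methoxyphenyl, gives a number 6.8 percentage points lower from compound 2 to compound 3 (within the scatter), so these two groups are not separated at this place, para to a large group. The drop seen with chloro is therefore not unique to chloro, since methoxy in place of hydrogen gives a number 37 percentage points lower from compound 1 to compound 3 (beyond the scatter) as well. No measurement available here explains this shared behaviour. Still open, going by these compounds, is whether an amine or a carboxylic acid at this place would give a similarly low number. Also open, on these data alone, is whether chloro or methoxy would act alike on the other phenyl ring.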